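Pyrrolidinyl in place of methyl on the amide chain

The source may hold more compounds than are shown below. What is called first, only, known or untested is meant among the compounds shown, and "the series" means these compounds.

Of the compounds shown here, three sharing one core have been measured in an ADME assay on BHK cells (Mesocricetus auratus) for cytotoxicity, read by MTT assay, with a stated time of 96 h; a higher number here means that more compound is tolerated, a lower number that less compound is tolerated. Compound 1 `CCC(=O)Nc1ccc(-c2nc3cc(C(F)(F)F)ccc3n2C2CCCCC2)cc1` gives 15000 nM. Compound 2 `CCC(=O)Nc1ccc(-c2nc3cc(C(F)(F)F)ccc3[nH]2)cc1`, with hydrogen in place of cyclohexyl on an aromatic nitrogen, gives 100000 nM, the higher of the two numbers on record, reached by a 6.7-fold higher number from compound 1 to compound 2 (0.82 log units; beyond the scatter). Compound 3 `CCC(=O)Nc1ccc(-c2nc3cc(C(F)(F)F)ccc3n2C)cc1` reaches only the limit of this assay, at > 100000 nM. That limit is the one described as the limit of > 100000 nM in this assay, at which 1 of the 3 values shown sits.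

Compound 4 `O=C(CN1CCCC1)Nc1ccc(-c2nc3cc(C(F)(F)F)ccc3[nH]2)cc1` differs from compound 2 by pyrrolidin-1-yl in place of methyl on a saturated chain carbon bound to a carbonyl carbon. Going by the values given here, none of the measured steps touches this part of the molecule; all three concern the substituent on the aromatic nitrogen, so they offer no direct guide to the size of the present change. Among the compounds with values here, with no bearing step available, no change beyond the scatter is expected, and compound 2 already sits at the top of the measured range. Compound 4 is therefore estimated to give 85000 nM, between 40000 nM and 100000 nM. The expected step is a 1.2-fold lower number from compound 2 to compound 4 (0.07 log units; within the scatter), within the scatter.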

Compound 4, half-maximal cytotoxic concentration: 29000 nM
Compound 4: the middle estimate sits 2.9-fold (0.47 log units) above what was measured; measured number outside the range, below it.
By their numbers in this assay, from the lowest: compounds 1 and 4 (each within the scatter of the next); then compound 2.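

In this assay the amide chain proves to be a place that moves the number: pyrrolidin-1-yl in place of methyl on a saturated chain carbon bound to a carbonyl carbon gives a 3.4-fold lower number from compound 2 to compound 4 (0.54 log units; beyond the scatter). Going by these compounds alone, every earlier step concerned the substituent on an aromatic nitrogen, so this is the first sign that the amide chain counts as well, and here the group with five heavy atoms and one hydrogen-bond acceptor goes with less compound tolerated than methyl. Nothing measured here offers a cause for this step.

On these data alone, whether the fall follows the ring, its nitrogen or the added atoms stays open; a dimethylamino group, a cyclopentyl ring or a longer carbon chain in the same place would separate these. Also open, as far as these compounds go, is whether the step holds when methyl or cyclohexyl sits on the aromatic nitrogen.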